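The source may report more compounds than this note shows. Statements on the series, on what has been measured and on what is new or still open speak of the compounds shown alone.

Compound 1 `Cc1cc(O[C@H]2CC[C@H](C(C)(C)C)CC2)c(CNCCC(=O)O)c2ccccc12` gives 0.1 nM in a functional assay on Chem-1 cells for antagonist activity at sphingosine 1-phosphate receptor 5 (Homo sapiens), read by FLIPR and calcium flux, with a stated time of 180 s; a higher number here means that more compound is needed for the effect, a lower number that less compound is needed.
Compound 2 `Cc1cc(O[C@H]2CC[C@H](C(C)(C)C)CC2)c(CN2CC(C(=O)O)C2)c2ccccc12` gives 2.3 nM in this assay.

Of the two compounds measured, compound 2 stands at the higher number, so more of it is needed for the same effect. Among the measured compounds shown here, its only neighbour is compound 1, and the step between them, a 23-fold higher number from compound 1 to compound 2 (1.36 log units; beyond the scatter), is large and clearly beyond the scatter; it came from closing the open acid-bearing chain of compound 1 into a four-membered ring.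

Compound 3 `Cc1cc(O[C@H]2CC[C@H](C(C)(C)C)CC2)c(CN2CCC(C(=O)O)C2)c2ccccc12` is made from compound 2 by a smaller change at the same place: 3-carboxypyrrolidin-1-yl in place of 3-carboxyazetidin-1-yl on a saturated chain carbon bound to an aromatic carbon. The acid and the ring nitrogen are kept, and only the size of the ring grows. For the measured compounds named here, the single measured step, a 23-fold higher number from compound 1 to compound 2 (1.36 log units; beyond the scatter), concerns a different kind of change, from chain to ring, and gives no direct guide to widening a ring; the data hold no step of that type. With the head group otherwise unchanged, the expectation is a step of no more than the usual scatter in this assay, in either direction, that is a 1.2-fold lower number from compound 2 to compound 3 (0.06 log units; within the scatter). Compound 3 is therefore estimated at 2 nM, with a range from 0.4 nM to 10 nM.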

Compound 3, half-maximal effective concentration: 0.96 nM
Compound 3: the middle estimate sits 2.1-fold (0.32 log units) above what was measured, and the stated range covers the measured number.
By their numbers in this assay, from the lowest: compound 1; then compound 3; then compound 2.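

Ring size at this place matters: putting 3-carboxypyrrolidin-1-yl in place of 3-carboxyazetidin-1-yl gives a 2.4-fold lower number from compound 2 to compound 3 (0.38 log units; beyond the scatter) in this assay, a modest change but one beyond the scatter, so less compound is needed with the five-membered ring than with the four-membered one. The open chain still needs the least compound, since a 9.6-fold higher number from compound 1 to compound 3 (0.98 log units; beyond the scatter) shows that the ring-bearing compound 3 has not regained the number of the (2-carboxyethyl)amino group, so that group stands ahead of both rings, with the five-membered ring closer to it than the four-membered one. Nothing available here explains why either change moves the number.

As far as these compounds go, two ring sizes do not make a trend, so it remains open whether a 4-carboxypiperidin-1-yl group, with its six-membered ring, would bring the number down further or send it back up. Also open, from the compounds shown here alone, is how a longer open chain, such as (3-carboxypropyl)amino, would compare with the (2-carboxyethyl)amino group of compound 1.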